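From Isopropyl to Pentan-3-yl on Compound 1

The compounds below may be only part of what the source reports. "The series", "measured", "known", "first", "only" and "open" are said of these compounds alone.

Of the compounds shown here, two have been measured in an ADME assay on the whole organism for inhibition, with Oryza sativa as the target, with a stated time of 4 days; a lower number here means a stronger inhibitor, a higher number a weaker inhibitor. Compound 1 `CC(C)Nc1nc(Cl)nc(N[C@@H](C)c2ccccc2)n1` gives 23400 nM, the higher of the two numbers. Compound 2 `CC(C)Nc1nc(Cl)nc(N[C@H](C)c2ccccc2)n1` shares every atom and bond with compound 1 and differs only in the configuration drawn at the saturated chain carbon; in this assay compound 2 gives 5370 nM. The step of a 4.4-fold lower number from compound 1 to compound 2 (0.64 log units; beyond the scatter) is the only one measured, and its structural basis is the fact that compounds 1 and 2 differ only in the configuration as drawn.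

Compound 3 `CCC(CC)Nc1nc(Cl)nc(N[C@@H](C)c2ccccc2)n1` keeps the configuration of compound 1 and alters the alkyl group on the ring nitrogen: pentan-3-yl in place of isopropyl on a nitrogen on an aromatic ring. The measured step between compound 1 and compound 2 concerns configuration alone and leaves the isopropyl group untouched, so it offers no guidance on exchanging that group for pentan-3-yl. For the measured compounds named here, with no step of this kind among the measured compounds, the reviewer expects nothing beyond the scatter in this assay for compound 3, and accordingly estimates a 1.2-fold lower number from compound 1 to compound 3 (0.07 log units; within the scatter). For compound 3 in this assay the reviewer therefore estimates 20000 nM, with a range from 6000 nM to 60000 nM.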

Compound 3, half-maximal inhibitory concentration: 35500 nM
Compound 3: middle estimate off by 1.8-fold (0.25 log units), on the low side; the measured number falls inside the stated range.
By their numbers in this assay, from the lowest: compound 2; then compounds 1 and 3 (each within the scatter of the next).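

In this assay, pentan-3-yl in place of isopropyl on a nitrogen on an aromatic ring gives a 1.5-fold higher number from compound 1 to compound 3 (0.18 log units; within the scatter), so at this position, with the configuration of compound 1 held fixed, the exchange to the group with more carbon atoms leaves the number within the scatter. This is the first reading of any change to this alkyl group, and it sets the exchange apart from the only step shown that lies beyond the scatter, the change of configuration alone, a 4.4-fold lower number from compound 1 to compound 2 (0.64 log units; beyond the scatter). Nothing in the information given accounts for this result, and no measured property of either alkyl group bears on it.

The compounds shown leave open whether pentan-3-yl would read the same way on the configuration of compound 2, where the isopropyl compound gives the lower number of that pair. They also leave open how other groups on this nitrogen would read in this assay, such as a methyl group, a cyclohexyl ring, a longer unbranched chain or a chain ending in a carboxylic acid.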